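Ethyl in Place of Chloro on a Shared Core

The compounds below may be only part of what the source reports. "The series", "measured", "known", "first", "only" and "open" are said of these compounds alone.

Three measured compounds share one core: compound 1 `COc1ccc(CNc2cc(-c3ccco3)nc(Cl)n2)cc1`, compound 2 `COc1ccc(CNc2ncnc(-c3ccco3)c2NC=O)cc1` and compound 3 `COc1ccc(CNc2nc(Cl)nc(-c3ccco3)c2NC=O)cc1`. Their cytotoxicity was tested in an ADME assay on Vero cells (Chlorocebus sabaeus) for cytotoxicity, read by MTT assay, with a stated time of 72 h; on this read-out higher numbers stand for weaker inhibition and lower numbers for stronger inhibition. For compound 1 the result is "not determined" (no result reported). Compound 2 reaches only the limit of the assay, > 40 ug/mL. Compound 3 likewise stops at the limit, > 40 ug/mL. The step that the two limits leave unreadable from compound 2 to compound 3 therefore cannot be sized, since (the limit of > 40 ug/mL in this assay, at which 2 of the 3 values shown sit). Compound 4 `CCc1nc(NCc2ccc(OC)cc2)c(NC=O)c(-c2ccco2)n1` differs from compound 3 by ethyl in place of chloro on an aromatic carbon. For the measured compounds named here, no measured step maps onto this exchange, and the single neighbouring comparison is unreadable. Compound 4 is therefore expected to stay near the limit, with the step that the limit leaves unreadable from compound 3 to compound 4 expected to be no larger than the scatter. The estimate for compound 4 is 50 ug/mL, expected to lie between 20 ug/mL and 150 ug/mL.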

Compound 4, half-maximal inhibitory concentration: > 40 ug/mL
Compound 4 gave a limit, no number (the forecaster's own chance of this, stated with the estimate: 75%); the middle value lies beyond the limit too.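

Compound 2, compound 3 and compound 4 each stop at a limit rather than a number, so no step among them can be read: the limit of > 40 ug/mL in this assay, at which 3 of the 4 values shown sit.

From the compounds shown here alone, how far hydrogen, chloro or ethyl on that aromatic carbon truly differ in cytotoxicity stays open.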